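Loss of a ring methyl on the sulfonamide aryl group

The compounds below may be only part of what the source reports. "The series", "measured", "known", "first", "only" and "open" are said of these compounds alone.

Compound 3 `Cc1ccc(C)c(NS(=O)(=O)c2ccc(N3CCNC3=O)cc2)c1` gives the lowest number of the three measured compounds, 48 nM in a functional assay on MCF7 cells (Homo sapiens) for antiproliferative activity, read by sulforhodamine B assay, with a stated time of 48 h; on this read-out higher numbers stand for weaker inhibition and lower numbers for stronger inhibition. Compound 2 `Cc1ccc(NS(=O)(=O)c2ccc(N3CCNC3=O)cc2)c(C)c1` gives 230 nM and compound 1 `CCc1ccccc1NS(=O)(=O)c1ccc(N2CCNC2=O)cc1` gives 350 nM. Compound 4 `Cc1ccc(NS(=O)(=O)c2ccc(N3CCNC3=O)cc2)cc1` differs from compound 3 by 4-methylphenyl in place of 2,5-dimethylphenyl on a sulfonamide nitrogen. The step that bears most on this change is a 4.8-fold lower number from compound 2 to compound 3 (0.68 log units; beyond the scatter), which shows that moving one methyl on this ring alone shifts the number well beyond the scatter; a 7.3-fold lower number from compound 1 to compound 3 (0.86 log units; beyond the scatter) points the same way, while a 1.5-fold lower number from compound 1 to compound 2 (0.18 log units; within the scatter) does not. Since compound 4 keeps a methyl pattern closer to compound 2 and drops the second methyl, a higher number is expected, a 6.3-fold higher number from compound 3 to compound 4 (0.80 log units; beyond the scatter), giving an estimated 300 nM for compound 4, with a range from 100 nM to 1000 nM.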

Compound 4, half-maximal inhibitory concentration: 610 nM
Beside the measured number, compound 4's estimate is 2.0-fold (0.31 log units) below it, and the stated range covers the measured number.
By their numbers in this assay, from the lowest: compound 3; then compounds 2, 1 and 4 (each within the scatter of the next, the first and the last beyond it).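

For the compounds shown here, on this ring, 4-methylphenyl in place of 2,5-dimethylphenyl gives a 13-fold higher number from compound 3 to compound 4 (1.10 log units; beyond the scatter) and is the largest step so far. Hydrogen in place of methyl on an aromatic carbon also counts, giving a 2.7-fold higher number from compound 2 to compound 4 (0.42 log units; beyond the scatter) beyond the scatter, so the second methyl of the 2,4-dimethylphenyl group matters too. By contrast, 4-methylphenyl in place of 2-ethylphenyl gives a 1.7-fold higher number from compound 1 to compound 4 (0.24 log units; within the scatter) and stays within the scatter. From the compounds shown here alone, whether a methoxy group or a chlorine atom could stand in for a ring methyl remains open. Nothing shown here explains why these numbers shift.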